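Replacing dichlorophenyl with methylphenyl on the shared core

A few compounds are considered here, and "the series" means these few. Any claim that something is new, unique, unknown or untested is made for them only; others in the source may bear on it.

Compound 3 `NC1=NC2(CCOCC2)N(OCCCOc2ccc(Cl)cc2Cl)C(N)=N1` gives 880 nM in a functional assay on HCT-116 cells (Homo sapiens) for antiproliferative activity, read by MTT assay, with a stated time of 72 h (a higher number here means a weaker inhibitor, a lower number a stronger inhibitor), and so sits within the scatter of compound 2 `NC1=NC2(CCOCC2)N(OCCCOc2ccc(Cl)cc2)C(N)=N1` (690 nM) and well clear of compound 1 `NC1=NC2(CCOCC2)N(OCCCOc2ccccc2)C(N)=N1` (6010 nM). Compound 4 `Cc1ccc(OCCCON2C(N)=NC(N)=NC23CCOCC3)cc1` differs from compound 3 as follows: 4-methylphenyl in place of 2,4-dichlorophenyl on an oxygen on a saturated carbon and so has 4-methylphenyl in place of 2,4-dichlorophenyl on an oxygen on a saturated carbon. Chloro in place of hydrogen on an aromatic carbon gave an 8.7-fold lower number from compound 1 to compound 2 (0.94 log units; beyond the scatter) and then a 1.3-fold higher number from compound 2 to compound 3 (0.11 log units; within the scatter) while the full replacement of phenyl gave a 6.8-fold lower number from compound 1 to compound 3 (0.83 log units; beyond the scatter) overall. Among the compounds with values here, no compound with methyl has been measured, and compound 4 carries no chloro, so a small rise in the number is expected. The estimated step is a 1.6-fold higher number from compound 3 to compound 4 (0.20 log units; within the scatter) and is expected to stay within the scatter. In this assay the expected value of compound 4 is 1400 nM with a range of 500 nM to 4000 nM as an estimate.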

Compound 4, half-maximal inhibitory concentration: 2390 nM
For compound 4 the middle estimate is 1.7-fold (0.23 log units) below the measured one, within the range that was stated.
By their numbers in this assay, from the lowest: compounds 2 and 3 (each within the scatter of the next); then compound 4; then compound 1.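

In this assay, a methyl group on the aromatic carbon still improves on plain phenyl, with a 2.5-fold lower number from compound 1 to compound 4 (0.40 log units; beyond the scatter), but it does not match chloro, with a 3.5-fold higher number from compound 2 to compound 4 (0.54 log units; beyond the scatter). Replacing the whole ring substituent pattern gives a 2.7-fold higher number from compound 3 to compound 4 (0.43 log units; beyond the scatter), so the choice of 4-methylphenyl over 2,4-dichlorophenyl on this oxygen matters beyond the scatter, which the chloro compounds alone could not show. No measurement here explains this difference.

From the compounds shown here alone, it remains open whether a fluoro or methoxy group on the same aromatic carbon would track with chloro or with methyl. Going by these compounds, the effect of a longer chain also remains open.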